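The source may report more compounds than this note shows. Statements on the series, on what has been measured and on what is new or still open speak of the compounds shown alone.

Among the compounds with values here, in a functional assay on cells (Homo sapiens) for cytotoxicity, read by sulforhodamine B assay, with a stated time of 2 days (a higher number here means a weaker inhibitor, a lower number a stronger inhibitor), compound 1 (`Cc1cc(N(C)C)ccc1-c1nc2c(s1)[C@H](O)CCC2`) gives 230 nM, the higher of the two numbers so far. Compound 2 (`OCc1cc(N2CCCC2)ccc1-c1nc2c(s1)C(O)CNC2`) gives 60 nM, and this gap lies beyond the scatter. Compound 3 (`Cc1cc(N(C)C)ccc1-c1nc2c(s1)[C@@H](O)CCC2`) departs from compound 1 in configuration alone: the two compounds have the same atoms and bonds and differ only in configuration as drawn: 1 of 1 stereo elements differ; a stereocentre at a saturated ring carbon is drawn R in compound 1 and S in compound 3. The two compounds have the same atoms and bonds, and a stereocentre at a saturated ring carbon is drawn R in compound 1 and S in compound 3. Within the data shown here, no measured pair shows what inverting this centre does, and compound 2 has no configuration drawn at its hydroxyl-bearing carbon, so the direction remains open. The expected step of a 1.1-fold higher number from compound 1 to compound 3 (0.04 log units; within the scatter) stays within the scatter, although a larger move either way cannot be excluded. Compound 3 is estimated at 250 nM, with an expected range from 100 nM to 600 nM.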

Compound 3, half-maximal inhibitory concentration: 1160 nM
The estimate for compound 3 lay 4.6-fold (0.67 log units) below the measured number, and the stated range ends below it.
By their numbers in this assay, from the lowest: compound 2; then compound 1; then compound 3.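

In this assay this saturated ring carbon proves sensitive to configuration: inversion from R to S gives a 5.0-fold higher number from compound 1 to compound 3 (0.70 log units; beyond the scatter). The cause of this step can be narrowed to the stereocentre, because nothing else separates the pair: the fact that compounds 1 and 3 differ only in the configuration as drawn. Within this pair, the R form is therefore the stronger inhibitor, a preference that the earlier compounds could not show, though it rests on a single pair and says nothing about how the configuration acts.

On these data alone, whether the same preference holds for compound 2, which has no configuration drawn at its hydroxyl-bearing carbon, remains open. Also open, as far as these compounds go, is whether the hydroxyl itself matters, since the effect of a methoxy group, an amine or a carbonyl at this carbon cannot be judged from these compounds.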